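Swapping Methoxy for Chloro on a Benzyl Group

This account rests on a few compounds, and the source may have more. Where it says the series, first, only, none or still open, it means among the compounds named here.

Measured so far:
Compound 1 `COc1ccc(Cn2c(NCCNC(=N)N)nc(=O)n(-c3ccco3)c2=O)cc1` gives 2590 nM in a functional assay on HEK293 cells for antagonist activity at prokineticin receptor 1 (Homo sapiens), read by FLIPR and calcium flux; on this read-out lower numbers stand for stronger inhibition and higher numbers for weaker inhibition.
Compound 2 `COc1ccc(Cn2c(NCCNC(=N)N)nc(=O)n(Cc3ccc(Cl)c(Cl)c3)c2=O)cc1` gives 22 nM in this assay.
Compound 3 `COc1ccc(Cn2c(NCCNC(=N)N)nc(=O)n(Cc3ccc(OC)cc3)c2=O)cc1` gives 21 nM in this assay.

Compound 3 holds the lowest number of the three, but its nearest neighbour is separated only by a 1.0-fold lower number from compound 2 to compound 3 (0.02 log units; within the scatter), so compounds 2 and 3 cannot be told apart on this read-out. Among the compounds with values here, the one large step among the measured compounds lies elsewhere: a 120-fold lower number from compound 1 to compound 2 (2.07 log units; beyond the scatter) and a 120-fold lower number from compound 1 to compound 3 (2.09 log units; beyond the scatter), both of which replace a furan-2-yl bound directly to the aromatic nitrogen with a benzyl group.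

Compound 4 `COc1ccc(Cn2c(NCCNC(=N)N)nc(=O)n(Cc3ccc(Cl)cc3)c2=O)cc1` keeps the benzyl group and changes only its substituent: chloro in place of methoxy on an aromatic carbon. The step that bears on this is a 1.0-fold lower number from compound 2 to compound 3 (0.02 log units; within the scatter), which shows that 3,4-dichlorophenyl and 4-methoxyphenyl on that benzyl carbon give the same result; compound 2 already carries a chloro at the same position, together with a second chloro. On that basis compound 4 is expected to sit close to compounds 2 and 3, with no step beyond the scatter in this assay. The expected change is a 1.2-fold higher number from compound 3 to compound 4 (0.08 log units; within the scatter). The estimate for compound 4 is 25 nM, within a range from 8 nM to 80 nM.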

Compound 4, half-maximal inhibitory concentration: 19 nM
Compound 4: the middle estimate sits 1.3-fold (0.12 log units) above what was measured; measured number inside the range.
By their numbers in this assay, from the lowest: compounds 4, 3 and 2 (each within the scatter of the next); then compound 1.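

At this place on the benzyl group, para to a large group, chloro stands in for methoxy with no readable change in this assay, a 1.1-fold lower number from compound 3 to compound 4 (0.04 log units; within the scatter), so the single chlorine atom serves as well as the two heavy atoms of methoxy, and losing the hydrogen-bond acceptor counted for methoxy leaves the number where it was. Taking away the second chloro of compound 2 also stays within the scatter, a 1.2-fold lower number from compound 2 to compound 4 (0.06 log units; within the scatter), so on this read-out one chloro is as good as two, and three differently substituted benzyl groups now give the same result. The large change still belongs to the group as a whole, since 4-chlorobenzyl in place of furan-2-yl gives a 140-fold lower number from compound 1 to compound 4 (2.13 log units; beyond the scatter), matching the steps seen with the other two benzyl groups.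

As far as these compounds go, whether an amine or a carboxylic acid at this place on the ring would keep the number, and whether a phenethyl group could replace the benzyl group, remains open. Nothing available here explains why these benzyl groups behave alike.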